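From Chloro to Trifluoromethyl on the Shared Core

A few compounds are considered here, and "the series" means these few. Any claim that something is new, unique, unknown or untested is made for them only; others in the source may bear on it.

In a functional assay on the whole organism (strain Sprague-Dawley) for inhibition, with Rattus norvegicus as the target, with a stated time of 10 min (on this read-out lower numbers stand for an effect already at smaller amounts and higher numbers for an effect only at larger amounts of compound), compound 1 (`O=C(O)c1cnc(-c2ccccc2)[nH]c1=O`) gives 50 mg/kg, compound 2 (`CCCOc1ccccc1-c1ncc(C(=O)O)c(=O)[nH]1`) gives 0.9 mg/kg and compound 3 (`O=C(O)c1cnc(-c2ccc(Cl)cc2)[nH]c1=O`) gives 5 mg/kg. Compound 3 therefore holds the second highest of the three numbers. Compound 4 (`O=C(O)c1cnc(-c2ccc(C(F)(F)F)cc2)[nH]c1=O`) has not yet been measured. It carries trifluoromethyl in place of chloro on an aromatic carbon, para to a large group: trifluoromethyl in place of chloro on an aromatic carbon.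

Going by the values given here, two measured steps bear on this change. The step with chloro in place of hydrogen is a 10-fold lower number from compound 1 to compound 3 (1.00 log units; beyond the scatter), which is modest. The step with propoxy in place of hydrogen is a 56-fold lower number from compound 1 to compound 2 (1.74 log units; beyond the scatter), which is large. Both go towards lower numbers, but they start from hydrogen and involve other groups. Among the compounds with values here, no measured step replaces chloro, and none introduces trifluoromethyl, so the evidence for this exchange is indirect. The closest guide is the modest chloro step, and compound 4 is expected to keep the lower number seen there, with no clear shift in either direction. The estimate amounts to no change at the digits printed from compound 3 to compound 4 (within the scatter), so no change beyond the scatter is expected. Compound 4 is expected at 5 mg/kg, with an estimated range from 1.5 mg/kg to 20 mg/kg.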

Compound 4, dose for 50% inhibition: > 5 mg/kg
Compound 4: only a limit was reported; the forecaster's own chance of this, stated with the estimate: 3%; the middle value sits exactly at the limit.
By their numbers in this assay, from the lowest: compound 2; then compound 3; then compound 1.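

For compound 4, the reading in this assay is a limit and not a number: > 5 mg/kg. At this place on the six-membered aromatic ring of carbon only, para to a large group, trifluoromethyl in place of chloro gives a number no lower from compound 3 to compound 4 (the limit leaves the size open), the first direct exchange shown here between two substituents rather than a replacement of hydrogen, and it gives no sign that trifluoromethyl brings a lower number than chloro. The other new step, with trifluoromethyl in place of hydrogen, cannot be read, so the result does not show whether trifluoromethyl keeps any of the move towards lower numbers that chloro gave, and the whole reading rests on one limit: the limit of > 5 mg/kg in this assay, at which 1 of the 4 values shown sits.

The compounds shown leave open where the number for compound 4 really lies, and so whether trifluoromethyl stays close to chloro at this position or falls back towards hydrogen. They also leave open how an amine or a methoxy group would read at this same position on the shared core.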